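Thiosemicarbazones on B16 Cells: Chloro Gives Way to Hydroxy

A few compounds are considered here, and "the series" means these few. Any claim that something is new, unique, unknown or untested is made for them only; others in the source may bear on it.

Measured in a functional assay on B16 cells (Mus musculus) for inhibition; a higher number here means a weaker inhibitor, a lower number a stronger inhibitor:
Compound 1 `CC(C)(C)c1ccc(/C=N/NC(N)=S)cc1` — 2700 nM
Compound 2 `Cc1cccc(/C=N/NC(N)=S)c1` — 2800 nM
Compound 3 `NC(=S)N/N=C/c1cccc(Cl)c1` — 2400 nM

Compound 3 has the lowest number of the three, yet its gaps to compound 1 and compound 2 both fall within the scatter, so the three cannot be told apart in this assay. Compound 4 `NC(=S)N/N=C/c1cccc(O)c1` differs from compound 3 by hydroxy in place of chloro on an aromatic carbon. Among the compounds with values here, the only measured step at that aromatic carbon, a 1.2-fold lower number from compound 2 to compound 3 (0.07 log units; within the scatter), stayed within the scatter; no measured step involves a hydroxy group, so nothing directly informs this change. Compound 4 is therefore expected to show a step of a 1.3-fold higher number from compound 3 to compound 4 (0.10 log units; within the scatter), none beyond the scatter. For compound 4 the estimate in this assay is 3000 nM, expected within 1200 nM to 7500 nM.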

Compound 4, half-maximal inhibitory concentration: 24000 nM
The estimate for compound 4 lay 8.0-fold (0.90 log units) below the measured number; the measured number lies above the stated range.
By their numbers in this assay, from the lowest: compounds 3, 1 and 2 (each within the scatter of the next); then compound 4.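

At this aromatic carbon, chloro and methyl could not be told apart in this assay, but hydroxy can: the change gives a 10-fold higher number from compound 3 to compound 4 (1.00 log units; beyond the scatter) and, against methyl, an 8.6-fold higher number from compound 2 to compound 4 (0.93 log units; beyond the scatter), both beyond the scatter. The position therefore responds to the group it carries, and hydroxy, which unlike chloro brings a hydrogen-bond donor and a hydrogen-bond acceptor, stands apart from the other two. Nothing available explains this step.

On these data alone, whether methoxy or an amine at this carbon would side with hydroxy or with chloro and methyl remains open.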